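The source may hold more compounds than are shown below. What is called first, only, known or untested is meant among the compounds shown, and "the series" means these compounds.

Working notes on the series. Three compounds sharing one core have been run in an ADME assay on Huh-7 cells (Homo sapiens) for cytotoxicity, read by MTT assay, with a stated time of 48 h; on this read-out lower numbers stand for higher toxicity in this test and higher numbers for lower toxicity in this test. Compound 1 `CN(C)CCCCOC(=O)Nc1ccc(Cn2nc(-c3ccc(C#N)cc3)c3ccccc3c2=O)cc1` gives 37000 nM. Compound 2 `CN(C)CCCCOC(=O)Nc1ccc(Cn2nc(-c3cccc(C(F)(F)F)c3)c3ccccc3c2=O)cc1` gives 11600 nM in this assay. Compound 3 `CN(C)CCCCOC(=O)Nc1ccc(Cn2nc(-c3ccccc3F)c3ccccc3c2=O)cc1` gives 52500 nM in this assay. Of the three numbers, compound 3 holds the highest; its gap to compound 1 lies within the scatter, and only its gap to compound 2 lies beyond it.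

Compound 4 `CN(C)CCCCOC(=O)Nc1ccc(Cn2nc(-c3ccccc3C(F)(F)F)c3ccccc3c2=O)cc1` has not yet been measured in this assay. It differs from compound 3 in a single place: trifluoromethyl in place of fluoro on an aromatic carbon. Among the compounds with values here, no measured step makes exactly this exchange. Within the data shown here, the two steps that bear on it are those through compound 2, the one compound already carrying trifluoromethyl: a 3.2-fold lower number from compound 1 to compound 2 (0.50 log units; beyond the scatter) and a 4.5-fold higher number from compound 2 to compound 3 (0.66 log units; beyond the scatter). In both, compound 2 sits at the lower number, though each step also moves the substituent around the ring, so the read-across is loose. On that basis the step from compound 3 to compound 4 is expected to lower the number modestly, a 2.6-fold lower number from compound 3 to compound 4 (0.42 log units; beyond the scatter), with compound 2 as the anchor for how far it might go. Compound 4 is estimated at 20000 nM in this assay, with a range from 8000 nM to 55000 nM.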

Compound 4, half-maximal cytotoxic concentration: 35700 nM
The estimate for compound 4 lay 1.8-fold (0.25 log units) below the measured number; the range from low to high includes it.
By their numbers in this assay, from the lowest: compound 2; then compounds 4, 1 and 3 (each within the scatter of the next).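

In this assay, a 1.5-fold lower number from compound 3 to compound 4 (0.17 log units; within the scatter): at this place, on an aromatic carbon ortho to a large group, trifluoromethyl with its 4 heavy atoms and fluoro with its 1 heavy atom are not told apart. The low number of compound 2 therefore does not follow trifluoromethyl as such, since a 3.1-fold higher number from compound 2 to compound 4 (0.49 log units; beyond the scatter), a step beyond the scatter in which only the placement of the group on the phenyl ring changes, while a 1.0-fold lower number from compound 1 to compound 4 (0.02 log units; within the scatter) leaves 2-(trifluoromethyl)phenyl and 4-cyanophenyl indistinguishable in this test. No measurement at hand accounts for the gap between the two trifluoromethyl compounds.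

Within the data shown here, compound 2 is the only compound with 3-(trifluoromethyl)phenyl, so it remains open whether its low number belongs to that placement generally or to this one compound alone. Also open, from the compounds shown here alone, is how far the flat result at this place extends to groups of another kind, such as a primary amine, a hydroxyl or a carboxylic acid on the same aromatic carbon.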